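A few compounds are considered here, and "the series" means these few. Any claim that something is new, unique, unknown or untested is made for them only; others in the source may bear on it.

Measured so far:

Compound 1 `Cc1cc(NC(=O)c2ccc(Cl)cc2)ccc1NS(=O)(=O)C(F)(F)F`: in an ADME assay on HEK293 cells (Homo sapiens) for cytotoxicity, read by MTT assay, with a stated time of 48 h (a lower number here means a stronger inhibitor, a higher number a weaker inhibitor), compound 1 gives 201000 nM.

Compound 2 `Cc1cc(NC(=O)c2ccc(C#N)cc2)ccc1NS(=O)(=O)C(F)(F)F`: in this assay compound 2 gives > 250000 nM, which is a limit of the assay rather than a number.

Compound 3 `CCS(=O)(=O)Nc1ccc(NC(=O)c2ccc(Cl)cc2)cc1OC`: in this assay compound 3 gives > 250000 nM, again a limit of the assay rather than a number.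

Within this set, the one change seen twice is cyano in place of chloro on an aromatic carbon. On the core of compound 1 it gave an at least 1.2-fold higher number from compound 1 to compound 2 (0.09 log units; that floor lies within the scatter), and the end point is only a bound, because of the limit of > 250000 nM in this assay, at which 2 of the 3 values shown sit.

Compound 4 `CCS(=O)(=O)Nc1ccc(NC(=O)c2ccc(C#N)cc2)cc1OC` carries the same change on the core of compound 3: cyano in place of chloro on an aromatic carbon. The difference between the two cores is not broken down here. With compound 3 already at its bound, the step from compound 3 to compound 4 is expected to be small, roughly a step that the limit leaves unreadable from compound 3 to compound 4, resting on the earlier step of an at least 1.2-fold higher number from compound 1 to compound 2 (0.09 log units; that floor lies within the scatter). Compound 4 is estimated at 300000 nM, most likely reported again as a limit.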

Compound 4, half-maximal inhibitory concentration: > 250000 nM
Compound 4: a limit, no number; the forecaster's own chance of this, stated with the estimate: 85%; the middle value is on the limit's open side.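

No step can be read from compound 3 to compound 4, because both stand at a limit, not a number: the limit of > 250000 nM in this assay, at which 3 of the 4 values shown sit.

Going by these compounds, what stays open is how far cyano in place of chloro really moves the number on the core of compound 3.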